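Extending a Methyl on Compound 2: Expected Cell Toxicity

A few compounds are considered here, and "the series" means these few. Any claim that something is new, unique, unknown or untested is made for them only; others in the source may bear on it.

Compound 1 `CCCCc1ccc(-c2ccc3ncc(-c4noc(C)n4)cc3c2)cc1` — > 2500 nM
Compound 2 `CCc1ccc(-c2ccc3ncc(-c4noc(C)n4)cc3c2)cc1` — > 7400 nM
Compound 3 `Cc1ccc(-c2ccc3ncc(-c4noc(C)n4)cc3c2)cc1` — > 7400 nM

In a functional assay on RD cells (Homo sapiens) for inhibition, read by luminescence and ATP content, with a stated time of 72 h (on this read-out lower numbers stand for higher toxicity in this test and higher numbers for lower toxicity in this test), compound 1 gives > 2500 nM, which is a limit of the assay rather than a number. Compound 2 gives > 7400 nM, also a limit. Compound 3 gives > 7400 nM, again a limit. So compound 2 stands at the limit of > 7400 nM in this assay, at which 2 of the 3 values shown sit, while the only other reading is the limit of > 2500 nM in this assay, at which 1 of the 3 values shown sits. The steps among these three, a step that the two limits leave unreadable from compound 1 to compound 2, a step that the two limits leave unreadable from compound 1 to compound 3 and a step that the two limits leave unreadable from compound 2 to compound 3, cannot be sized, since each end is a limit.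

Compound 4 `CCc1ccc(-c2ccc3ncc(-c4noc(CC)n4)cc3c2)cc1` differs from compound 2 by methyl in place of hydrogen on a saturated chain carbon bound to an aromatic carbon. The measured steps that bear on it are those three unreadable ones; they show that changing the length of a short alkyl chain on the shared core left every value beyond the range measured. No step beyond the scatter is therefore expected in this assay for a step that the limit leaves unreadable from compound 2 to compound 4. Compound 4 is estimated at 10000 nM, within a range from 3000 nM to 40000 nM, most likely reported only as a limit.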

Compound 4, half-maximal cytotoxic concentration: > 22200 nM
Compound 4: a limit, no number; the forecaster's own chance of this, stated with the estimate: 85%; middle value at least 2.2-fold (0.34 log units) away from the limit.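

Compound 2 and compound 4 both stand at limits of the assay rather than at numbers, so the step between them cannot be read. The compounds shown leave open whether, and at what concentration, any of them becomes toxic in this assay.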